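This account rests on a few compounds, and the source may have more. Where it says the series, first, only, none or still open, it means among the compounds named here.

Values in a functional assay on SW1573 cells (Homo sapiens) for antiproliferative activity, read by sulforhodamine B assay, with a stated time of 48 h (on this read-out higher numbers stand for weaker inhibition of growth and lower numbers for stronger inhibition of growth), for the measured compounds:
- compound 1 `CCCCC(C#CC(=O)OC)O/C=C/C(=O)OC` gives 240 nM 
- compound 2 `CCC(C#CC(=O)OC)O/C=C/C(=O)OC` gives 540 nM 
- compound 3 `COC(=O)C#CC(O/C=C/C(=O)OC)C1CCCCC1` gives 2100 nM 

Compound 3 has the highest number of the three, so it inhibits growth the least, and its steps to both others lie beyond the scatter. Compound 4 `COC(=O)C#CC(CC(C)C)O/C=C/C(=O)OC` carries isobutyl in place of cyclohexyl on a saturated chain carbon bound to an oxygen on an unsaturated carbon and a triple-bonded carbon. Two modest measured steps bear on this change at the same carbon. Cyclohexyl in place of butyl gave an 8.8-fold higher number from compound 1 to compound 3 (0.94 log units; beyond the scatter) and cyclohexyl in place of ethyl gave a 3.9-fold higher number from compound 2 to compound 3 (0.59 log units; beyond the scatter) in this assay as well. Isobutyl, like butyl and ethyl, has no ring, so a step of similar size in the opposite direction, to a lower number, is expected. The expected step is a 5.3-fold lower number from compound 3 to compound 4 (0.72 log units; beyond the scatter) by this estimate. Within the data shown here, no measured compound carries isobutyl itself, so the range stays wide. For compound 4 the expected value is 400 nM with an estimated range from 170 nM to 950 nM in this assay once tested.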

Compound 4, concentration for 50% growth inhibition: 380 nM
Beside the measured number, compound 4's estimate is 1.1-fold (0.02 log units) above it, and the stated range covers the measured number.
By their numbers in this assay, from the lowest: compounds 1, 4 and 2 (each within the scatter of the next, the first and the last beyond it); then compound 3.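

Isobutyl in place of cyclohexyl gives a 5.5-fold lower number from compound 3 to compound 4 (0.74 log units; beyond the scatter) in this assay, so a branched chain without a ring falls with the straight chains here, which butyl and ethyl alone could not show. The branch makes no readable difference from either straight chain, with a 1.4-fold lower number from compound 2 to compound 4 (0.15 log units; within the scatter) and a 1.6-fold higher number from compound 1 to compound 4 (0.20 log units; within the scatter), so compound 4 cannot be placed in order against compound 1 or compound 2. Nothing available explains why cyclohexyl stands apart from these chains.

The compounds shown leave open whether any ring at this carbon would give a number like that of compound 3, as cyclopentyl and phenyl lie outside the set. They also leave open how a chain longer than butyl, or one ending in an amine or a carboxylic acid, would behave there.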